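This account rests on a few compounds, and the source may have more. Where it says the series, first, only, none or still open, it means among the compounds named here.

Compound 1 `O=C(O)COc1ccc(NC(=O)COc2ccccc2)cc1F` stands second highest of the three numbers measured in a functional assay on CHO cells for agonist activity at Free fatty acid receptor 1 (Homo sapiens), read by FLIPR, tested at 100 nM (on this read-out lower numbers stand for a weaker effect and higher numbers for a stronger effect at the one concentration tested), where compound 1 gives 29.8%. Its nearest neighbour is compound 3 `CC(Oc1ccccc1)C(=O)Nc1ccc(OCC(=O)O)c(F)c1`, which gives 35.7%; the step of a number 5.9 percentage points higher from compound 1 to compound 3 (within the scatter) lies within the scatter. Compound 2 `O=C(O)COc1ccc(NC(=O)Nc2ccccc2)cc1F` gives 8.47%, a number beyond the scatter below that of compound 1.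

Compound 4 `Cc1ccc(OCC(=O)Nc2ccc(OCC(=O)O)c(F)c2)cc1` differs from compound 1 by methyl in place of hydrogen on an aromatic carbon, read one bond further out as phenoxy to 4-methylphenoxy. Among the measured compounds shown here, no measured step in this set puts a methyl on an aromatic carbon. For the measured compounds named here, the only single-place step available, a number 5.9 percentage points higher from compound 1 to compound 3 (within the scatter), puts a methyl on a saturated chain carbon instead and stays within the scatter, so it bears on the present change only loosely. On that basis no step beyond the scatter is expected in this assay in either direction.

Compound 4 is therefore estimated to give 31%, with a range from 14% to 48%, which means an expected a number 1.2 percentage points higher from compound 1 to compound 4 (within the scatter).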

Compound 4, a percentage reported as activity, at one concentration (the size of the read-out at that concentration, not a potency): 31.2%
The estimate for compound 4 lay 0.2 percentage points below the measured number, within the range that was stated.
By their numbers in this assay, from the lowest: compound 2; then compounds 1, 4 and 3 (each within the scatter of the next).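

In this assay the change of phenoxy to 4-methylphenoxy gives a number 1.4 percentage points higher from compound 1 to compound 4 (within the scatter), so this aromatic position, para to a large group, takes a methyl with no step beyond the scatter at the one concentration tested. Set beside a number 5.9 percentage points higher from compound 1 to compound 3 (within the scatter), where the methyl sits on a saturated chain carbon, this means that neither methyl placement shown moves the number beyond the scatter. Nothing available gives a reason for this result.

The compounds shown leave open whether a larger or different group in the same place, such as an ethyl, a methoxy, a chlorine or a trifluoromethyl, would change the number beyond the scatter. They also leave open whether compound 1 and compound 4 differ in potency, as the read-out gives the size of the effect at one concentration only.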